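Swapping an Amine for an Amide on the Shared Core

This account rests on a few compounds, and the source may have more. Where it says the series, first, only, none or still open, it means among the compounds named here.

Compound 1 `CNCc1ccc2c(c1)nc(Cn1c(=O)n(C(C)C)c3ccccc31)n2CCC(C)C` — 1480 nM
Compound 2 `CNCc1ccc2nc(Cn3c(=O)n(C(C)C)c4ccccc43)n(CCC(C)C)c2c1` — 4810 nM
Compound 3 `COC(=O)c1cccc2c1nc(Cn1c(=O)n(C(C)C)c3ccccc31)n2CCC(C)C` — 49200 nM

In an ADME assay on HEp-2 cells (Homo sapiens) for cytotoxicity (a higher number here means that more compound is tolerated, a lower number that less compound is tolerated), compound 1 gives 1480 nM, the lowest of the three numbers shown. Its nearest neighbour is compound 2, which gives 4810 nM, a gap beyond the scatter, and the furthest is compound 3, which gives 49200 nM, a much wider gap. Compound 4 `CC(C)CCn1c(Cn2c(=O)n(C(C)C)c3ccccc32)nc2cc(C(=O)N(C)C)ccc21` is not yet measured. It differs from compound 1 in one place: dimethylcarbamoyl in place of (methylamino)methyl on an aromatic carbon. The entering dimethylcarbamoyl group carries no hydrogen-bond donor, whereas the leaving (methylamino)methyl group carries one. The expectation is that compound 4 is tolerated more than compound 1, with a step of a 10-fold higher number from compound 1 to compound 4 (1.01 log units; beyond the scatter) in this assay that goes beyond the scatter, partly because compound 3 gives 49200 nM in this assay while also lacking a hydrogen-bond donor at its aromatic carbon. Compound 4 is therefore estimated at 15000 nM, within a range from 4000 nM to 60000 nM.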

Compound 4, half-maximal cytotoxic concentration: 25600 nM
For compound 4 the middle estimate is 1.7-fold (0.23 log units) below the measured one; low and high end bracket the measured number.
By their numbers in this assay, from the lowest: compound 1; then compound 2; then compounds 4 and 3 (each within the scatter of the next).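

In this assay, among the compounds shown here, dimethylcarbamoyl in place of (methylamino)methyl on this aromatic carbon gives a 17-fold higher number from compound 1 to compound 4 (1.24 log units; beyond the scatter), the only step here between compounds that differ in one place, and it shows that the group at this position can move the number well beyond the scatter. The change removes the hydrogen-bond donor, adds heavy atoms and brings in a double bond outside aromatic rings, while the hydrogen-bond acceptor count and the absence of net charge stay the same. No measurement here links the step to any one of these differences.

The compounds shown leave open whether the step follows the lost donor or the entering carbonyl: methylcarbamoyl keeps the amide hydrogen, whereas (dimethylamino)methyl has neither that hydrogen nor a carbonyl. As far as these compounds go, how a carboxylic acid on this carbon would read also remains open.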